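Methoxy placement on the arylpiperazine: compound 3 to compound 4

A few compounds are considered here, and "the series" means these few. Any claim that something is new, unique, unknown or untested is made for them only; others in the source may bear on it.

The series shares the core of compound 1 `O=C(CCCN1CCN(c2ccccc2)CC1)Nc1ccc(Cl)cc1`, which in an assay on HEK293 cells for inhibition of Voltage-dependent T-type calcium channel subunit alpha-1G (Homo sapiens), read by patch clamp (on this read-out lower numbers stand for stronger inhibition and higher numbers for weaker inhibition), gives 4470 nM. Compound 2 `O=C(CCCN1CCN(c2ccc(Cl)cc2)CC1)Nc1ccc(Cl)cc1` gives 2640 nM in this assay, and compound 3 `COc1ccccc1N1CCN(CCCC(=O)Nc2ccc(Cl)cc2)CC1` gives 2610 nM, the lowest of the three numbers, though within the scatter of both others. Compound 4 `COc1cccc(N2CCN(CCCC(=O)Nc3ccc(Cl)cc3)CC2)c1` differs from compound 3 by 3-methoxyphenyl in place of 2-methoxyphenyl on an amine nitrogen in a ring. The steps that touch the aryl substituent, a 1.7-fold lower number from compound 1 to compound 3 (0.23 log units; within the scatter), a 1.7-fold lower number from compound 1 to compound 2 (0.23 log units; within the scatter) and a 1.0-fold lower number from compound 2 to compound 3 (0.00 log units; within the scatter), all stayed within the scatter. Nothing here separates the 2-methoxyphenyl from the 3-methoxyphenyl, so no step beyond the scatter is expected in this assay. Compound 4 is therefore estimated at 2800 nM, range 1200 nM to 6500 nM, which means an expected step of a 1.1-fold higher number from compound 3 to compound 4 (0.03 log units; within the scatter).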

Compound 4, half-maximal inhibitory concentration: 2780 nM
Compound 4: middle estimate off by 1.0-fold (0.00 log units), on the high side, and the stated range covers the measured number.
By their numbers in this assay, from the lowest: compounds 3, 2, 4 and 1 (each within the scatter of the next).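

Swapping 2-methoxyphenyl for 3-methoxyphenyl gives a 1.1-fold higher number from compound 3 to compound 4 (0.03 log units; within the scatter) in this assay, so the methoxy placement tested here produces no readable difference at this position. The 3-methoxyphenyl also stays level with 4-chlorophenyl, with a 1.1-fold higher number from compound 2 to compound 4 (0.02 log units; within the scatter) on that swap, and adding its methoxy to the plain phenyl gives a 1.6-fold lower number from compound 1 to compound 4 (0.21 log units; within the scatter), so no aryl group shown stands apart. No available evidence explains this flat response. Still open, going by these compounds, is whether an amine or a carboxylic acid on this aryl group, or a longer chain to the amide, gives a step beyond the scatter.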